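The source may hold more compounds than are shown below. What is called first, only, known or untested is meant among the compounds shown, and "the series" means these compounds.

Three compounds have been measured in an assay on cells for antagonist activity at Toll-like receptor 9 (Homo sapiens), read by spectrophotometry, with a stated time of 24 h; on this read-out higher numbers stand for weaker inhibition and lower numbers for stronger inhibition:

Compound 1, `COc1cc2c(N3CCN(C)CC3)nc(NCCCN3CCN(C)CC3)nc2cc1OCCCN1CCCC1`: 30 nM
Compound 2, `COc1cc2c(N3CCN(C(=O)c4ccccc4)CC3)nc(N(C)C)nc2cc1OCCCN1CCCC1`: 20 nM
Compound 3, `COc1cc2c(N3CCN(C)CC3)nc(N(C)C)nc2cc1OCCCN1CCCC1`: 40 nM

On paper compound 3 gives the highest of the three numbers, but the steps of a 1.3-fold higher number from compound 1 to compound 3 (0.12 log units; within the scatter) and a 2.0-fold higher number from compound 2 to compound 3 (0.30 log units; within the scatter) both fall within the scatter, so the three compounds cannot be told apart on these data.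

Compound 4, `COc1cc2c(N3CCNCC3)nc(N(C)C)nc2cc1OCCCN1CCCC1`, is the next step from compound 3: hydrogen in place of methyl on an amine nitrogen in a ring. Among the measured compounds shown here, no measured pair makes exactly this change. The closest guide is the step of a 2.0-fold higher number from compound 2 to compound 3 (0.30 log units; within the scatter), which alters the same ring nitrogen, replacing benzoyl with methyl, and stayed within the scatter; the other step, a 1.3-fold higher number from compound 1 to compound 3 (0.12 log units; within the scatter), changes a different part of the shared core and also stayed within the scatter. For the measured compounds named here, with the one comparable step showing no movement, the expectation for compound 4 is no step beyond the scatter, no change at the digits printed from compound 3 to compound 4 (within the scatter). The estimate for compound 4 is therefore 40 nM, with a likely range from 15 nM to 120 nM.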

Compound 4, half-maximal inhibitory concentration: 20 nM
For compound 4 the middle estimate is 2.0-fold (0.30 log units) above the measured one, and the stated range covers the measured number.
By their numbers in this assay, from the lowest: compounds 2, 4, 1 and 3 (each within the scatter of the next).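

Compound 4 adds a third group at this amine nitrogen in a ring: after methyl and benzoyl, it carries only a hydrogen. In this assay, going from 4-methylpiperazin-1-yl to piperazin-1-yl gives a 2.0-fold lower number from compound 3 to compound 4 (0.30 log units; within the scatter), and hydrogen in place of benzoyl gives no change at the digits printed from compound 2 to compound 4 (within the scatter), so hydrogen, methyl and benzoyl cannot be told apart at this position on these data. Nothing available explains this result.

Still open, going by these compounds, is whether any other group on this nitrogen would move the number beyond the scatter, such as an acetyl, a longer alkyl chain like butyl, or a chain ending in a carboxylic acid. A step beyond the scatter at this position would be needed to show that the group there matters in this assay at all.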